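The compounds below may be only part of what the source reports. "The series", "measured", "known", "first", "only" and "open" are said of these compounds alone.

Compound 1 `COc1ccc(-c2nc(SCC(=O)c3sc(-c4ccccc4)nc3C)[nH]c(=O)c2C#N)cc1`: 52.1%
Compound 2 `Cc1nc(-c2ccc(Cl)cc2)sc1C(=O)CSc1nc(N)c(C#N)c(-c2ccc(Cl)cc2)n1`: 15.5%
Compound 3 `COc1ccc(-c2nc(C)c(C(=O)CSc3nc(-c4ccc(Cl)c(Cl)c4)c(C#N)c(=O)[nH]3)s2)cc1`: 78.4%

Of the compounds shown here, three have been measured in a functional assay on U-87MG ATCC cells for antiproliferative activity against U-87 MG (Homo sapiens), read by MTT assay, with a stated time of 48 h, tested at 50 uM; a lower number here means a stronger effect, a higher number a weaker effect of the compound at the concentration tested. Compound 2 gives the lowest of the three numbers; compound 1, its nearest neighbour, lies higher by a margin beyond the scatter, and compound 3 lies higher still, also beyond the scatter. Compound 4 `Cc1nc(-c2ccccc2)sc1C(=O)CSc1nc(N)c(C#N)c(-c2ccc(Cl)cc2)n1` has not yet been measured. It differs from compound 2 in one place: hydrogen in place of chloro on an aromatic carbon. Within the data shown here, no measured pair differs by this change alone, so nothing shows how large the step is, and compound 1 differs from compound 4 in more than one place, which leaves it unfit as a guide. The step from compound 2 to compound 4 is expected to be a modest rise, a number 9.5 percentage points higher from compound 2 to compound 4 (within the scatter), perhaps within the scatter. Compound 4 is therefore estimated at 25%, in a range from 8% to 50%.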

Compound 4, a percentage reported as activity, at one concentration (the size of the read-out at that concentration, not a potency): 44.3%
Compound 4: the middle estimate sits 19.3 percentage points below what was measured, within the range that was stated.
By their numbers in this assay, from the lowest: compound 2; then compounds 4 and 1 (each within the scatter of the next); then compound 3.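

In this assay, among these compounds, the change from 4-chlorophenyl to phenyl gives a number 28.8 percentage points higher from compound 2 to compound 4 (beyond the scatter) and is the first single change that can be read from a pair of compounds. It shows that the chloro on this aromatic carbon is not a neutral substituent, since removing it alone shifts the read-out beyond the usual scatter.

Going by these compounds, whether bromo or an amine on the same carbon would stay near compound 2 or near compound 4 remains open, as does the role of the other chloro, which compound 4 keeps. Nothing shown here accounts for the size of this step.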